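Urea to benzamide on a shared core: a limit-bound step

The source may hold more compounds than are shown below. What is called first, only, known or untested is meant among the compounds shown, and "the series" means these compounds.

Compound 3 `COc1cc(-c2nn(-c3cccc(NC(=O)Nc4cccc(C(F)(F)F)c4)c3)cc2-c2ccncc2)ccc1Cl` is measured in a functional assay on RPMI-8226 cells (Homo sapiens) for inhibition, read by sulforhodamine B assay, with a stated time of 48 h; a higher number here means that more compound is tolerated, a lower number that less compound is tolerated. For compound 3 the read-out is only a limit of the assay, > 50000 nM. Two relatives share the same core. For compound 1 `O=C(Nc1cccc(-n2cc(-c3ccncc3)c(-c3ccc(Cl)c(O)c3)n2)c1)Nc1ccc(Cl)c(Cl)c1` the assay gives only a limit, > 32500 nM. For compound 2 `COc1cc(-c2nn(-c3cccc(NC(=O)c4ccc(Cl)c(C(F)(F)F)c4)c3)cc2-c2ccncc2)ccc1Cl` the assay likewise gives only a limit, > 32500 nM. The step that the two limits leave unreadable from compound 2 to compound 3 cannot be read because the limit of > 32500 nM in this assay, at which 2 of the 3 values shown sit, and the limit of > 50000 nM in this assay, at which 1 of the 3 values shown sits, bound both of its ends. Compound 4 `COc1cc(-c2nn(-c3cccc(NC(=O)c4ccccc4)c3)cc2-c2ccncc2)ccc1Cl` differs from compound 3 by phenyl in place of (3-(trifluoromethyl)phenyl)amino on a carbonyl carbon. Within the data shown here, no measured step bears readably on this change, and every value shown is a limit. Compound 4 is therefore expected to sit at a limit as well, with an estimated step of a number no higher from compound 3 to compound 4 (the limit leaves the size open). The estimate for compound 4 is 50000 nM, between 15000 nM and 100000 nM.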

Compound 4, concentration lethal to 50% of the cells: > 100000 nM
Compound 4: a limit, no number (the forecaster's own chance of this, stated with the estimate: 80%); at least 2.0-fold (0.30 log units) between middle value and limit.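

The result for compound 4 is a limit and not a number, so neither its step from compound 2 nor its step from compound 3 can be read: the limit of > 100000 nM in this assay, at which 1 of the 4 values shown sits. On these data alone, whether phenyl, (3-(trifluoromethyl)phenyl)amino or 4-chloro-3-(trifluoromethyl)phenyl on the carbonyl carbon changes the lethal concentration stays open.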